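A few compounds are considered here, and "the series" means these few. Any claim that something is new, unique, unknown or untested is made for them only; others in the source may bear on it.

Of the compounds shown here, two have been tested in an assay on HEK293 cells for agonist activity at Toll-like receptor 8 (Homo sapiens); on this read-out lower numbers stand for an effect already at smaller amounts and higher numbers for an effect only at larger amounts of compound. Compound 1 `CCC[C@@H](CCO)Nc1nc(N)nc(C)c1Cc1ccc(CNCC(N)=O)cc1OC` carries a (carbamoylmethyl)amino group on a saturated chain carbon bound to an aromatic carbon. In this assay compound 1 reaches only the limit of > 10000 nM, which is a limit of the measurement and not a number. Compound 2 `CCC[C@@H](CO)Nc1nc(N)nc(C)c1Cc1ccc(CNC)cc1OC` differs from it in more than one place; in this assay compound 2 gives 2140 nM. Compound 3 `CCC[C@@H](CCO)Nc1nc(N)nc(C)c1Cc1ccc(Cn2ccnc2)cc1OC` is not yet measured. It differs from compound 1 by 1H-imidazol-1-yl in place of (carbamoylmethyl)amino on a saturated chain carbon bound to an aromatic carbon. Among the compounds with values here, with compound 1 sitting at the limit (the limit of > 10000 nM in this assay, at which 1 of the 2 values shown sits), no measured step in this assay can guide the size of the change; any outcome from well below the limit to the limit itself remains open, so the expected direction is a modest gain at most. The estimate for compound 3 in this assay is 4000 nM, between 800 nM and 20000 nM, corresponding to an expected step of an at least 2.5-fold lower number from compound 1 to compound 3 (0.39 log units; beyond the scatter).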

Compound 3, half-maximal effective concentration: 4900 nM
For compound 3 the middle estimate is 1.2-fold (0.09 log units) below the measured one; measured number inside the range.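

With 1H-imidazol-1-yl in place of (carbamoylmethyl)amino on a saturated chain carbon bound to an aromatic carbon, the core of compound 1 now gives a true number in this assay, so this place can be read on a scale rather than only against a ceiling. The step is an at least 2.0-fold lower number from compound 1 to compound 3 (0.30 log units; that floor lies within the scatter), and because it is only a floor, the real size of the change may be larger but cannot be fixed. The value of compound 1 remains a limit of the measurement and not a number, and this is what keeps the step open-ended: the limit of > 10000 nM in this assay, at which 1 of the 3 values shown sits.

The compounds shown do not tell whether the aromatic ring itself or the loss of the hydrogen-bond donors matters more. A 1H-pyrazol-1-yl group, a dimethylamino group or a carboxylic acid at this place on the same core would help separate the two.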